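A few compounds are considered here, and "the series" means these few. Any claim that something is new, unique, unknown or untested is made for them only; others in the source may bear on it.

Measured compounds:
compound 1, `COc1cc(N)c(Cl)cc1C(=O)NCC(O)CN1CCC(CN2CCC(N)CC2)CC1`, 40.6 nM
compound 2, `COc1cc(N)c(Cl)cc1C(=O)NC1CCN(CC2CCN(C(=O)C(C)N)CC2)CC1`, 5.06 nM

Both compounds were tested in an assay on striatum for inhibition of 5-hydroxytryptamine receptor 4 (Cavia porcellus), read by radioligand binding; on this read-out lower numbers stand for stronger inhibition and higher numbers for weaker inhibition. Compound 1 gives 40.6 nM, and compound 2 gives 5.06 nM, the lower of the two numbers; the gap between them lies beyond the usual scatter, so on the two numbers at hand compound 2 shows the stronger inhibition. Among the measured compounds shown here, no pair differing in a single place has been measured, so no step of known size exists yet.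

Compound 3, `COc1cc(N)c(Cl)cc1C(=O)NC1CCN(CC2CCN(CCCNS(C)(=O)=O)CC2)CC1`, has not yet been measured in this assay. It is derived from compound 2 by one change: 3-(methanesulfonamido)propyl in place of (1-aminoethyl)carbonyl on an amine nitrogen in a ring. The shared core and the rings are kept; only the group on that ring nitrogen is exchanged. For the measured compounds named here, with no measured step to lean on, the expectation rests on compound 2 alone, whose value 5.06 nM sets the starting point. The expected step is a 1.3-fold lower number from compound 2 to compound 3 (0.10 log units; within the scatter), within the scatter or a little toward a lower number. Compound 3 is therefore estimated to give about 4 nM in this assay, with a plausible range from 1 nM to 15 nM.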

Compound 3, half-maximal inhibitory concentration: 21.1 nM
The estimate for compound 3 lay 5.3-fold (0.72 log units) below the measured number; measured number above the stated range.
By their numbers in this assay, from the lowest: compound 2; then compounds 3 and 1 (each within the scatter of the next).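

In this assay, putting 3-(methanesulfonamido)propyl in place of (1-aminoethyl)carbonyl on the amine nitrogen in the six-membered non-aromatic ring gives a 4.2-fold higher number from compound 2 to compound 3 (0.62 log units; beyond the scatter) and thereby provides the only step of known size among these compounds. It shows that the number at this position responds to the group on that nitrogen, even though both groups have the same printed counts of hydrogen-bond donors and acceptors, carry no net charge and contain no ring, so those shared counts alone do not fix the value here. The entering group differs in having more heavy atoms and in containing sulfur, but no measurement is at hand that explains the size of this step.

As far as these compounds go, it remains open whether a plain propyl chain, a 3-aminopropyl group or a shorter 2-(methanesulfonamido)ethyl chain on this nitrogen would give a number closer to that of compound 2 or that of compound 3. Also open, from the compounds shown here alone, is whether a carboxylic acid at the end of such a chain, or an acetyl group on the same nitrogen, would change the number in either direction.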